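Working notes toward compound 3

The source may report more compounds than this note shows. Statements on the series, on what has been measured and on what is new or still open speak of the compounds shown alone.

Measured so far:
compound 1, `O=C1C=CC(=O)C(c2cc(-c3ccc(C(=O)N4CCC(C(F)(F)F)CC4)s3)on2)=C1`, > 30000 nM in a functional assay on PC-3 cells (Homo sapiens) for cytotoxicity, read by XTT assay, with a stated time of 72 h; on this read-out lower numbers stand for stronger inhibition and higher numbers for weaker inhibition
compound 2, `O=C1C=CC(=O)C(c2cc(-c3ccc(C(=O)N4CCCCC4)s3)on2)=C1`, > 30000 nM in this assay

In this assay compound 1 gives only a limit, > 30000 nM. Compound 2 likewise gives only a limit in this assay, > 30000 nM. Among the compounds with values here, compound 2 thus stands at the limit, and the one further value shown sits there as well, (the limit of > 30000 nM in this assay, at which 2 of the 2 values shown sit). Within the data shown here, the single measured step, a step that the two limits leave unreadable from compound 1 to compound 2, is accordingly unreadable in size and direction.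

Compound 3, `CCCN(C)C(=O)c1ccc(-c2cc(C3=CC(=O)C=CC3=O)no2)s1`, differs from compound 2 by methyl(propyl)amino in place of piperidin-1-yl on a carbonyl carbon. Among the measured compounds shown here, no measured step gives a readable size for a change of this kind, so no direction can be drawn from the series. With both measured values at the limit (the limit of > 30000 nM in this assay, at which 2 of the 2 values shown sit), the expectation for compound 3 is that this assay again reports a limit rather than a number. Compound 3 is therefore estimated at 30000 nM, with a range of 10000 nM to 100000 nM. The estimated step of a number no higher from compound 2 to compound 3 (the limit leaves the size open) is expected to stay within the scatter.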

Compound 3, half-maximal inhibitory concentration: < 30000 nM
Compound 3 gave a limit, no number (the forecaster's own chance of this, stated with the estimate: 80%); the middle value sits exactly at the limit.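

In this assay compound 3 gives < 30000 nM, which is a limit and not a number. The carbonyl carbon is thus the first place in the series where a change shows a direction, though no size, as open-chain methyl(propyl)amino replaces the ring amines: a number no higher from compound 2 to compound 3 (the limit leaves the size open), and a number no higher from compound 1 to compound 3 (the limit leaves the size open). Compound 3 alone carries a limit of this kind: the limit of < 30000 nM in this assay, at which 1 of the 3 values shown sits.

On these data alone, with no number for compound 3, the size of the change from piperidin-1-yl to methyl(propyl)amino, and whether it goes beyond the usual scatter, stays open. Also open, as far as these compounds go, is how dimethylamino or a longer chain such as methyl(butyl)amino on the same carbonyl carbon would read in this assay, and so whether the open chain itself matters.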